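Swapping 4-Nitrophenyl for 3-Phenylprop-2-en-1-yl on a Ring Nitrogen

A few compounds are considered here, and "the series" means these few. Any claim that something is new, unique, unknown or untested is made for them only; others in the source may bear on it.

Of the compounds shown here, two have so far been measured in a functional assay on the whole organism (blood) with Rattus norvegicus as the target, at a dose of 100 mg/kg by the oral route; on this read-out lower numbers stand for less inhibition and higher numbers for more inhibition at the one dose given (going by the name of the read-out). Compound 1 `N#Cc1ccc(OCC(O)CN2CCN(c3ccccc3)CC2)cc1` gives 56.7%. Compound 2 `O=[N+]([O-])c1ccc(N2CCN(CC(O)COc3ccc(Cl)cc3)CC2)cc1` gives 24.8%, the lowest of the two numbers, and its gap to compound 1 lies beyond the usual scatter of this kind of measurement. Compound 3 `OC(COc1ccc(Cl)cc1)CN1CCN(C/C=C/c2ccccc2)CC1` has not yet been measured. It differs from compound 2 at a single place: 3-phenylprop-2-en-1-yl in place of 4-nitrophenyl on an amine nitrogen in a ring. Going by the values given here, no measured pair shows this particular exchange, so its effect cannot be read off other compounds; the only guide is that compound 2 sits at the low end of the two numbers seen. A moderate rise, somewhat beyond the scatter, is expected, though with wide uncertainty in both directions. For compound 3 an inhibition of about 37% is estimated, within a range from 12% to 65%. The expected step is a number 12.2 percentage points higher from compound 2 to compound 3 (beyond the scatter).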

Compound 3, a percentage reported as inhibition, in the whole organism at one dose (the size of the read-out at that dose, not a potency): 14.6%
The estimate for compound 3 lay 22.4 percentage points above the measured number, within the range that was stated.
By their numbers in this assay, from the lowest: compound 3; then compound 2; then compound 1.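

Going by these compounds alone, on this assay the exchange of 4-nitrophenyl for 3-phenylprop-2-en-1-yl on the amine nitrogen in the ring gives a number 10.2 percentage points lower from compound 2 to compound 3 (beyond the scatter) and is the first direct reading of a change at this position, a modest step in the downward direction. The two groups match in heavy atoms and each carries one six-membered aromatic ring of carbon only, but the entering group is all carbon and has no hydrogen-bond acceptors, so matching those counts alone did not hold the number here. No supporting measurement explains this step.

Going by these compounds, it remains open whether a benzyl group or a chain ending in an amine at this nitrogen would raise or lower the number. Compound 1 differs from compound 2 and compound 3 in more than one place, so it cannot settle this.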